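Naphthalen-2-yl to 1-methyl-1H-indol-2-yl on the shared core

This account rests on a few compounds, and the source may have more. Where it says the series, first, only, none or still open, it means among the compounds named here.

Measured so far in an assay on isolated protein for binding affinity to melanin-concentrating hormone receptor 1 (Homo sapiens); on this read-out higher numbers stand for weaker inhibition and lower numbers for stronger inhibition:
compound 1 `COc1cc(OC)cc(C(=O)NC2CCN(Cc3ccc4ccccc4c3)CC2)c1` gives 27 nM
compound 2 `O=C(NC1CCN(Cc2ccc3ccccc3c2)CC1)c1ccc(F)cc1` gives 36 nM

Compound 1 and compound 2 sit within the scatter of each other in this assay, as the step of a 1.3-fold higher number from compound 1 to compound 2 (0.12 log units; within the scatter) shows; that step replaces the aryl group on the carbonyl carbon and leaves the rest of the core untouched.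

Compound 3 `COc1cc(OC)cc(C(=O)NC2CCN(Cc3cc4ccccc4n3C)CC2)c1` has not been measured. It differs from compound 1 in one place: 1-methyl-1H-indol-2-yl in place of naphthalen-2-yl on a saturated chain carbon bound to an amine nitrogen in a ring. For the measured compounds named here, no measured step touches this position, since the only step in hand, from compound 1 to compound 2, concerns the other end of the core. There is therefore no measured guide to the size or direction of the step from compound 1 to compound 3; the two groups match in heavy-atom count, and the entering group brings one hydrogen-bond acceptor where the leaving group had none.

Going by the values given here, with no direct precedent, a modest weakening of binding is expected for compound 3, with a wide range: estimate 60 nM (from 15 nM to 250 nM), a step of a 2.2-fold higher number from compound 1 to compound 3 (0.35 log units; beyond the scatter).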

Compound 3, inhibition constant: 142 nM
Compound 3: middle estimate off by 2.4-fold (0.37 log units), on the low side; the range from low to high includes it.
By their numbers in this assay, from the lowest: compounds 1 and 2 (each within the scatter of the next); then compound 3.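

In this assay, the aryl group on the saturated chain carbon bound to an amine nitrogen in a ring responds to a single replacement: 1-methyl-1H-indol-2-yl in place of naphthalen-2-yl gives a 5.3-fold higher number from compound 1 to compound 3 (0.72 log units; beyond the scatter) for this pair. For the compounds shown here, the only earlier step, a 1.3-fold higher number from compound 1 to compound 2 (0.12 log units; within the scatter) at the carbonyl carbon, left open whether any change on the shared core would move the number beyond the scatter, and this one does, even though both groups have the same heavy-atom count and differ in the five-membered aromatic ring with 1 hetero atom and the hydrogen-bond acceptor of the entering group. No evidence in hand ties this step to either of those differences, so its origin remains unassigned.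

Still open, on these data alone, is whether the step follows the methyl group or the aromatic ring system, which 1H-indol-2-yl without the methyl group, or quinolin-2-yl, would help to separate in this assay. Also open, as far as these compounds go, is whether 1-methyl-1H-indol-2-yl carries a similar step when 4-fluorophenyl replaces 3,5-dimethoxyphenyl on the carbonyl carbon.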